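Putting a Carboxylic Acid Back on the Amine Side Chain

The source may hold more compounds than are shown below. What is called first, only, known or untested is meant among the compounds shown, and "the series" means these compounds.

Compound 1 `O=C(O)c1ccc(CN2CCC[C@H](OCc3cc(Cl)cc(Cl)c3)[C@@H]2c2ccccc2)s1`: 76000 nM
Compound 2 `Clc1cc(Cl)cc(CO[C@H]2CCCN(Cc3ccccc3)[C@H]2c2ccccc2)c1`: > 200000 nM, a limit
Compound 3 `Clc1cc(Cl)cc(CO[C@H]2CCCN(Cc3ncco3)[C@H]2c2ccccc2)c1`: > 200000 nM, a limit

In an assay on isolated protein for activation of cGMP-dependent protein kinase 1 (Homo sapiens), read by ADP-Glo, with stated times of 120 min and 40 min (a lower number here means that less compound is needed, a higher number that more compound is needed for the effect), compound 1 gives 76000 nM. For compound 2 the assay reports only a limit, > 200000 nM. For compound 3 it likewise reports only a limit, > 200000 nM. Compound 3 thus sits at the limit of > 200000 nM in this assay, at which 2 of the 3 values shown sit, the highest position among the numbers shown.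

Compound 4 `O=C(O)c1cncc(CN2CCC[C@H](OCc3cc(Cl)cc(Cl)c3)[C@@H]2c2ccccc2)c1` differs from compound 3 by 5-carboxypyridin-3-yl in place of 1,3-oxazol-2-yl on a saturated chain carbon bound to an amine nitrogen in a ring, which brings back a carboxylic acid on that side chain, as in compound 1. The relevant steps are an at least 2.6-fold higher number from compound 1 to compound 3 (0.42 log units; beyond the scatter) and an at least 2.6-fold higher number from compound 1 to compound 2 (0.42 log units; beyond the scatter), while a step that the two limits leave unreadable from compound 2 to compound 3. Reversing the loss of the acid is therefore expected to lower the number in this assay, as an at least 2.2-fold lower number from compound 3 to compound 4 (0.34 log units; beyond the scatter). Compound 4 is estimated at 90000 nM, between 30000 nM and 250000 nM.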

Compound 4, half-maximal effective concentration: 117000 nM
Beside the measured number, compound 4's estimate is 1.3-fold (0.11 log units) below it; measured number inside the range.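

With a carboxylic acid on either ring at this place, on a saturated chain carbon bound to an amine nitrogen in a ring, the readings cannot be told apart: a 1.5-fold higher number from compound 1 to compound 4 (0.19 log units; within the scatter). Against the compounds without an acid, the new result gives only floors, an at least 1.7-fold lower number from compound 3 to compound 4 (0.23 log units; that floor lies within the scatter) and an at least 1.7-fold lower number from compound 2 to compound 4 (0.23 log units; that floor lies within the scatter). These stay floors because those two compounds stand at a limit: the limit of > 200000 nM in this assay, at which 2 of the 4 values shown sit. The compounds shown leave open whether an amide in place of the carboxylic acid would read the same. They also leave open what a longer chain between the ring and the acid would do.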